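A few compounds are considered here, and "the series" means these few. Any claim that something is new, unique, unknown or untested is made for them only; others in the source may bear on it.

Series notes, pendant-aryl position.

Of the compounds shown here, two have numbers so far. Compound 1 `COc1ccc(C2CC(=O)c3ccc(C)cc3O2)cc1` gives 3350 nM in an in vitro assay on BTI-TN-5B1-4 cells for inhibition of Amine oxidase [flavin-containing] B (Homo sapiens) (on this read-out lower numbers stand for stronger inhibition and higher numbers for weaker inhibition), and stands lowest of the two; its nearest neighbour is compound 2 `COc1ccc(C2CC(=O)c3ccc(OC)cc3O2)cc1`, which in this assay gives 7180 nM. Among the compounds with values here, the single measured step, a 2.1-fold higher number from compound 1 to compound 2 (0.33 log units; beyond the scatter), comes from methoxy in place of methyl on an aromatic carbon of the shared core and counts as modest.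

The step now under consideration goes from compound 1 to compound 3 `Cc1ccc2c(c1)OC(c1ccc(F)cc1)CC2=O`: fluoro in place of methoxy on an aromatic carbon, on an aromatic carbon of a six-membered aromatic ring of carbon only, para to a large group. Within the data shown here, no measured step touches this position or this exchange; the one step on record concerns a different ring and a different pair of groups, so it bears on the present case only as a general indication that single substituent exchanges have so far shifted this assay modestly. No direction can be read from it for compound 3.

For compound 3 the expectation is therefore a step of a 1.0-fold lower number from compound 1 to compound 3 (0.02 log units; within the scatter), within the scatter. Compound 3 is estimated at 3200 nM, with a range from 1200 nM to 8500 nM.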

Compound 3, half-maximal inhibitory concentration: 130 nM
Compound 3: middle estimate off by 25-fold (1.39 log units), on the high side; the whole stated range lies above it.
By their numbers in this assay, from the lowest: compound 3; then compound 1; then compound 2.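

At the pendant-aryl position, on an aromatic carbon para to a large group, fluoro in place of methoxy gives a 26-fold lower number from compound 1 to compound 3 (1.41 log units; beyond the scatter) in this assay. Within the data shown here, this exchange moves the number much further than the only earlier step, a 2.1-fold higher number from compound 1 to compound 2 (0.33 log units; beyond the scatter), which lies on the other ring, so single exchanges are no longer confined to modest shifts, and the pendant-aryl position is the more sensitive of the two places touched so far. Compound 3 now holds the lowest number of the three, but nothing on hand accounts for the size of this step.

With only methoxy and fluoro shown at this position, the compounds leave open whether the step follows from the departure of methoxy or the arrival of fluoro, a question that chloro, hydroxy, an amine or a longer chain such as ethoxy at the same carbon would help to settle. Also open, going by these compounds, is whether the same exchange carries over to the core of compound 2, which has methoxy in place of methyl.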